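Trimethoxyphenyl enamine on the pyrazolyl enone series

A few compounds are considered here, and "the series" means these few. Any claim that something is new, unique, unknown or untested is made for them only; others in the source may bear on it.

The three measured compounds share one core and differ in the two aryl groups. Compound 1 `COc1cc(N/C=C\C(=O)c2cn(-c3ccccc3)nc2-c2ccc(Cl)cc2)cc(OC)c1OC` gives 5640 nM in a functional assay on A549 cells (Homo sapiens) for antiproliferative activity, read by MTT assay, with a stated time of 48 h; a higher number here means a weaker inhibitor, a lower number a stronger inhibitor. Compound 2 `COc1cc(-c2nn(-c3ccccc3)cc2C(=O)/C=C\Nc2ccc(Cl)cc2)cc(OC)c1OC` gives 8670 nM. Compound 3 `COc1ccc(N/C=C\C(=O)c2cn(-c3ccccc3)nc2-c2cc(OC)c(OC)c(OC)c2)cc1` gives 4780 nM, the lowest of the three numbers, though within the scatter of compound 1 and of compound 2. For the measured compounds named here, the one single-place step recorded, a 1.8-fold lower number from compound 2 to compound 3 (0.26 log units; within the scatter), is small. Compound 1 and compound 3 differ in more than one place, so their values are only set side by side, and they lie close.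

Compound 4 `COc1cc(N/C=C\C(=O)c2cn(-c3ccccc3)nc2-c2cc(OC)c(OC)c(OC)c2)cc(OC)c1OC` carries 3,4,5-trimethoxyphenyl in place of 4-methoxyphenyl on an amine nitrogen. Going by the values given here, no measured step covers this change directly; the nearest reference is compound 1, which holds the same trimethoxyphenyl on the amine nitrogen and sits at 5640 nM, close to compound 3. Since the two enamine aryl variants seen so far lie within the scatter of one another, no step beyond the scatter is expected, a 1.0-fold higher number from compound 3 to compound 4 (0.00 log units; within the scatter). Compound 4 is therefore estimated at 4800 nM in this assay, in the range 2200 nM to 10500 nM.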

Compound 4, half-maximal inhibitory concentration: 7980 nM
Compound 4: middle estimate off by 1.7-fold (0.22 log units), on the low side; the measured number falls inside the stated range.
By their numbers in this assay, from the lowest: compounds 3, 1, 4 and 2 (each within the scatter of the next).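

On the amine nitrogen, with 3,4,5-trimethoxyphenyl held on the aromatic carbon, replacing 4-methoxyphenyl by 3,4,5-trimethoxyphenyl gives a 1.7-fold higher number from compound 3 to compound 4 (0.22 log units; within the scatter) in this assay and replacing 4-chlorophenyl by it gives a 1.1-fold lower number from compound 2 to compound 4 (0.04 log units; within the scatter) in the same read-out, so none of these three aryl groups is set apart at this position. On the aromatic carbon, with 3,4,5-trimethoxyphenyl held on the amine nitrogen, the same group in place of 4-chlorophenyl gives a 1.4-fold higher number from compound 1 to compound 4 (0.15 log units; within the scatter) and this second position also shows no step beyond the scatter. No measured evidence bearing on these steps is at hand.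

As far as these compounds go, whether any group on the amine nitrogen can produce a step beyond the scatter remains open. A carboxylic acid or a dimethylamino group on that phenyl ring, or a plain alkyl chain in its place, would test this.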